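The source may report more compounds than this note shows. Statements on the series, on what has been measured and on what is new or still open speak of the compounds shown alone.

Measured in a physicochemical assay for lipophilicity, read by spectrophotometry, using the shake flask method, in phosphate buffer, measured as octanol-water partition, with a stated time of 4 h, at pH 7.4; on this read-out lower numbers stand for lower lipophilicity and higher numbers for higher lipophilicity:
compound 1 `COc1ccc(Cn2nnc(O)c2C(=O)Nc2cccc(C(F)(F)F)c2)cc1` gives 1.1
compound 2 `COc1ccc(Cn2nnc(O)c2C(=O)Nc2cc(C(F)(F)F)cc(C(F)(F)F)c2)cc1` gives 2.47
compound 3 `COc1ccc(Cn2nnc(O)c2C(=O)Nc2ccc(-c3ccccc3)cc2)cc1` gives 2.19

Compound 1 has the lowest of these three numbers. Compound 4 `COc1ccc(Cn2nnc(O)c2C(=O)Nc2cccc(-c3ccccc3)c2)cc1` differs from it by one swap (phenyl in place of trifluoromethyl on an aromatic carbon), with phenyl in place of trifluoromethyl on an aromatic carbon. Among the measured compounds shown here, the only measured step between close relatives, a number 1.37 log units higher from compound 1 to compound 2 (beyond the scatter), is large, but it adds a trifluoromethyl rather than replacing one, so it is only a rough guide. Compound 3 also carries a phenyl, though not in the same place, and its value (2.19) lies beyond the scatter above that of compound 1. A large upward step is therefore expected in this assay, estimated as a number 1.00 log units higher from compound 1 to compound 4 (beyond the scatter) and beyond the scatter. Compound 4 is expected at 2.1, within an estimated range from 1.6 to 2.6.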

Compound 4, distribution coefficient: 2.3
Compound 4: the middle estimate sits 0.20 log units below what was measured; low and high end bracket the measured number.
By their numbers in this assay, from the lowest: compound 1; then compounds 3, 4 and 2 (each within the scatter of the next).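

In this assay, replacing the trifluoromethyl with phenyl on this aromatic carbon gives a number 1.20 log units higher from compound 1 to compound 4 (beyond the scatter) and so shows that a single swap at this position, with no group added elsewhere, can produce a large rise. The earlier step between close relatives came from adding a second trifluoromethyl, not from exchanging the first one. Nothing measured here explains the rise. Still open, going by these compounds, is whether an amine or a carboxylic acid at this position would stay near compound 1 or compound 4. A longer chain, which has no ring, could also show whether the aromatic ring of phenyl matters.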